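Ester Aryl Swap on the Shared Core: Compound 3 to 4

The source may hold more compounds than are shown below. What is called first, only, known or untested is meant among the compounds shown, and "the series" means these compounds.

The series shares a core; compound 1 `CC1=CC[C@H]2[C@@H]1CC=C(C)[C@@H](CCC1=C(C)CC[C@@H]3OC(C)(C)[C@@H](O)CC[C@@]13C)C2(C)C` carries no ester at all, compound 2 `CC(=O)O[C@H]1CC[C@]2(C)[C@H](CC[C@@](C)(O)[C@H]2CC[C@@H]2C(C)=CC[C@H]3[C@H](CC[C@]3(C)OC(C)=O)C2(C)C)OC1(C)C` two acetates, and compound 3 `CC1=CC[C@H]2[C@H](CC[C@]2(C)O)C(C)(C)[C@@H]1CC[C@H]1[C@]2(C)CC[C@H](OC(=O)c3ccncc3)C(C)(C)O[C@H]2CC[C@@]1(C)O` a pyridine-4-carboxylate. In a functional assay on MDA-MB-231 cells (Homo sapiens) for antiproliferative activity, read by MTT assay, with a stated time of 72 h (on this read-out higher numbers stand for weaker inhibition and lower numbers for stronger inhibition), compound 1 gives only a limit, > 50000 nM (the limit of > 50000 nM in this assay, at which 1 of the 3 values shown sits). In this assay compound 2 gives 26200 nM. In this assay compound 3 gives 18000 nM, the lowest of the two numbers, though the gap to compound 2 lies within the scatter, so no order between these two can be read.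

Compound 4 `CC1=CC[C@H]2[C@H](CC[C@]2(C)O)C(C)(C)[C@@H]1CC[C@H]1[C@]2(C)CC[C@H](OC(=O)c3ccc(C(F)(F)F)cc3F)C(C)(C)O[C@H]2CC[C@@]1(C)O` differs from compound 3 in one place: 2-fluoro-4-(trifluoromethyl)phenyl in place of pyridin-4-yl on a carbonyl carbon. Among the measured compounds shown here, no pair of measured compounds shows this kind of change, so its size is not anchored by any measured step. The expectation for this assay is a step from compound 3 to compound 4 that is small and toward a lower number, a 1.5-fold lower number from compound 3 to compound 4 (0.18 log units; within the scatter), but possibly none beyond the scatter. Compound 4 is therefore expected to give about 12000 nM, between 4000 nM and 40000 nM.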

Compound 4, half-maximal inhibitory concentration: 36300 nM
For compound 4 the middle estimate is 3.0-fold (0.48 log units) below the measured one; measured number inside the range.
By their numbers in this assay, from the lowest: compounds 3, 2 and 4 (each within the scatter of the next). At a limit, above all of these: compound 1.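

Among the compounds shown here, the exchange of pyridin-4-yl for 2-fluoro-4-(trifluoromethyl)phenyl on a carbonyl carbon gives a 2.0-fold higher number from compound 3 to compound 4 (0.30 log units; within the scatter) in this assay, the first single-place step. At this position, then, an aromatic ring with one hetero atom and one hydrogen-bond acceptor can give way to a carbon-only aromatic ring with fluorine substituents and no hydrogen-bond acceptor, with no change that can be read. Nothing shown accounts for the size of this step.

Steps among the other compounds cannot be read, since those compounds differ in more than one place. Still open, on these data alone, is whether an aminomethyl group on the aromatic ring, a carboxylic acid there, or a longer alkyl chain on the carbonyl carbon would move the read-out beyond the scatter.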